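This account rests on a few compounds, and the source may have more. Where it says the series, first, only, none or still open, it means among the compounds named here.

In a functional assay on Raji cells (Homo sapiens) for cytotoxicity, with a stated time of 72 h (a lower number here means that less compound is needed, a higher number that more compound is needed for the effect), compound 1 (`C=C[C@@](C)(/C=C/c1ccc(O)c(/C=C/C(=O)OCC)c1)CCC=C(C)C`) gives > 26000 nM as a limit of the assay, not a number. Compound 3 (`CCOC(=O)/C=C/c1cc(/C=C/[C@](C)(/C=C/c2ccc(OC)cc2)CCC=C(C)C)ccc1O`) gives > 26000 nM and this, too, is only a limit. It therefore stands at the limit of > 26000 nM in this assay, at which 2 of the 3 values shown sit, and has no exact value. Within the data shown here, compound 2 (`COc1ccc(/C=C/[C@@](C)(/C=C/c2ccc(O)c(C=O)c2)CCC=C(C)C)cc1`) gives 13000 nM as the only real number so far.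

The change to compound 4 (`COc1ccc(/C=C/[C@@](C)(/C=C/c2ccc(O)c(/C=C/C(=O)OC(C)(C)C)c2)CCC=C(C)C)cc1`) is tert-butyl in place of ethyl on an oxygen next to a carbonyl group. Two measured steps reach compound 3, but neither alters this group. Among the measured compounds shown here, the first is a step that the two limits leave unreadable from compound 1 to compound 3 and offers no size to work with. The second is an at least 2.0-fold higher number from compound 2 to compound 3 (0.30 log units; that floor lies within the scatter) and replaces formyl with 2-(ethoxycarbonyl)ethenyl.

Neither step gives a size for this exchange, so no change beyond the scatter is expected in this assay and the expected result is a number no higher from compound 3 to compound 4 (the limit leaves the size open) in plain terms. The estimated value for compound 4 is 26000 nM within an expected range of 11000 nM to 55000 nM and the assay may well report only a limit.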

Compound 4, half-maximal effective concentration: > 26000 nM
Compound 4: no number, only a limit; the forecaster's own chance of this, stated with the estimate: 60%; the middle value sits exactly at the limit.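

Exchanging ethyl for tert-butyl on this oxygen does not bring compound 4 off the limit in this assay, so the larger group yields no readable number either: the limit of > 26000 nM in this assay, at which 3 of the 4 values shown sit. The steps between limits cannot be read, so any real difference between ethyl and tert-butyl here stays hidden. Among these compounds, measured against the one real number in the set, the exchange of formyl for 2-(tert-butoxycarbonyl)ethenyl gives an at least 2.0-fold higher number from compound 2 to compound 4 (0.30 log units; that floor lies within the scatter), and this does not show a change beyond the scatter.

Going by these compounds, it remains open whether a methyl group on this oxygen would give a readable value. On these data alone, it is also open whether a free carboxylic acid or an amide in place of the ester would do so.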